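Oxime-to-acetyl exchange on the anilide arm of the series

The source may hold more compounds than are shown below. What is called first, only, known or untested is meant among the compounds shown, and "the series" means these compounds.

Measured so far, in a functional assay on the whole organism (strain albino) for inhibition, with Rattus norvegicus as the target, read by paw edema, with stated times of 30 min and 5 h, at a dose of 0.28 mmol/kg by the oral route; on this read-out higher numbers stand for more inhibition at the one dose given (going by the name of the read-out) and lower numbers for less inhibition:
compound 1, `C/C(=N\O)c1ccc(NC(=O)CSc2nnc(-c3ccccc3)n2-c2ccccc2)cc1`, gives 66%
compound 2, `COc1ccc(-c2nnc(SCC(=O)Nc3ccc(/C(C)=N/O)cc3)n2-c2ccccc2)cc1`, gives 58%
compound 3, `C=CCn1c(SCC(=O)Nc2ccc(/C(C)=N/O)cc2)nnc1-c1ccc(OC)cc1`, gives 72%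

Compound 2 gives the smallest of the three numbers, though it sits within the scatter of compound 1 and only the gap to compound 3 is beyond it. The step of a number 8 percentage points lower from compound 1 to compound 2 (within the scatter) is within the scatter. The step of a number 14 percentage points higher from compound 2 to compound 3 (beyond the scatter) is beyond the scatter and modest in size.

Compound 4, `COc1ccc(-c2nnc(SCC(=O)Nc3ccc(C(C)=O)cc3)n2-c2ccccc2)cc1`, differs from compound 2 in one place: a group of 3 heavy atoms (2 carbon, 1 oxygen; no ring) in place of a group of 4 heavy atoms (2 carbon, 1 nitrogen, 1 oxygen; no ring), on an aromatic carbon. Neither measured step touches this position; one changes a methoxy for hydrogen on an aromatic carbon, the other an allyl for a phenyl on an aromatic nitrogen. Among the compounds with values here, no measured step bears on the present change, so there is no basis from the series for a step in either direction in this assay.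

The expectation for compound 4 in this assay is therefore a number close to compound 2, with a step of a number 3 percentage points lower from compound 2 to compound 4 (within the scatter) expected to stay within the scatter. Compound 4 is estimated at 55%, with a range from 40% to 70%.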

Compound 4, a percentage reported as inhibition, in the whole organism at one dose (the size of the read-out at that dose, not a potency): 60%
For compound 4 the middle estimate is 5 percentage points below the measured one, within the range that was stated.
By their numbers in this assay, from the lowest: compounds 2, 4, 1 and 3 (each within the scatter of the next, the first and the last beyond it).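

Within the data shown here, the exchange of the group of 4 heavy atoms for acetyl, on an aromatic carbon para to a large group, is the first probe of this position in this assay, and it gives a number 2 percentage points higher from compound 2 to compound 4 (within the scatter). On the background of compound 2, the read-out at this one dose therefore does not separate the two groups, even though acetyl carries no hydrogen-bond donor. No supporting measurement is available to explain this result or to link it to either group.

From the compounds shown here alone, whether acetyl and the group it replaces also read alike on the background of compound 1 or compound 3 remains open. Equally open, going by these compounds, is how this position responds to a carboxylic acid, an amine or a longer chain on the same aromatic carbon.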